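The compounds below may be only part of what the source reports. "The series", "measured", "known", "first", "only" and "open" are said of these compounds alone.

In an ADME assay on Vero cells (Chlorocebus sabaeus) for cytotoxicity, read by neutral red uptake, with a stated time of 48 h (on this read-out lower numbers stand for stronger inhibition and higher numbers for weaker inhibition), compound 3 `Clc1ccc2c(NCCn3cnc4c(N5CCCCC5)nc(Cl)nc43)ccnc2c1` gives > 10700 nM as a limit only, not as a number. Compound 1 `CN(C)c1nc(Cl)nc2c1ncn2CCNc1ccnc2cc(Cl)ccc12` gives > 11800 nM as a limit too. Compound 2 `CCN(CC)c1nc(Cl)nc2c1ncn2CCNc1ccnc2cc(Cl)ccc12` gives > 11000 nM as a limit too. Compound 4 `Clc1ccc2c(NCCn3cnc4c(N5CCCCCC5)nc(Cl)nc43)ccnc2c1` differs from compound 3 by a single swap azepan-1-yl in place of piperidin-1-yl on an aromatic carbon in which azepan-1-yl stands in place of piperidin-1-yl on an aromatic carbon. The measured swaps at that place are a step that the two limits leave unreadable from compound 1 to compound 3 and a step that the two limits leave unreadable from compound 2 to compound 3 and also a step that the two limits leave unreadable from compound 1 to compound 2 so they offer no size to carry over. No step beyond the scatter is therefore expected in this assay in either direction. The expected change is an at least 1.0-fold lower number from compound 3 to compound 4 (0.01 log units; that floor lies within the scatter) on this estimate. For compound 4 the estimated value is 10400 nM with an expected range from 5000 nM to 20000 nM as its bounds.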

Compound 4, half-maximal inhibitory concentration: > 10400 nM
Compound 4: only a limit was reported; the forecaster's own chance of this, stated with the estimate: 80%; the middle value lies on the limit itself.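

Going by these compounds alone, compound 4, like compound 1, compound 2 and compound 3, is reported only as a limit, so no step between them can be read. From the compounds shown here alone, the true value of each compound, and any effect of swapping these groups, stays open.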